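A few compounds are considered here, and "the series" means these few. Any claim that something is new, unique, unknown or untested is made for them only; others in the source may bear on it.

Measured so far in an ADME assay on Vero cells (Chlorocebus sabaeus) for cytotoxicity, read by microscopy; a lower number here means that less compound is tolerated, a higher number that more compound is tolerated:
compound 1 `CSc1nc(NCCCNc2ccnc3cc(Cl)ccc23)c(C#N)c(-c2ccccc2)n1` gives 100000 nM
compound 2 `CSc1nc(NCCCCNc2ccnc3cc(Cl)ccc23)c(C#N)c(-c2ccccc2)n1` gives 20000 nM
compound 3 `CSc1nc(-c2ccc([N+](=O)[O-])cc2)c(C#N)c(N2CCN(c3ccnc4cc(Cl)ccc34)CC2)n1` gives 100000 nM

Compound 2 holds the lowest of the three numbers in this assay; compound 1 and compound 3 both sit higher, and both gaps lie beyond the scatter. Compound 4 `COc1ccc(-c2nc(SC)nc(NCCCCNc3ccnc4cc(Cl)ccc34)c2C#N)cc1` has not yet been measured in this assay. Its difference from compound 2: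
methoxy in place of hydrogen on an aromatic carbon
No pair of measured compounds differs in this one place, so the data shown give no direct reading of this change. The expected step is a 1.5-fold higher number from compound 2 to compound 4 (0.18 log units; within the scatter), a modest move toward a higher number that may well stay within the scatter. The estimate for compound 4 is 30000 nM, with a range from 10000 nM to 100000 nM.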

Compound 4, minimum cytotoxic concentration: 20000 nM
The estimate for compound 4 lay 1.5-fold (0.18 log units) above the measured number; measured number inside the range.
By their numbers in this assay, from the lowest: compounds 2 and 4 (each within the scatter of the next); then compounds 1 and 3 (each within the scatter of the next).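

In this assay, within the data shown here, the change from phenyl to 4-methoxyphenyl gives the first direct reading at this position, with no change at the digits printed from compound 2 to compound 4 (within the scatter) on the shared core. Methoxy in place of hydrogen on this aromatic carbon, para to a large group, therefore leaves the number within the scatter in this one pair. Nothing available explains this result.

On these data alone, whether any other group on this carbon would move the number remains open, for example an amine or a carboxylic acid. Also open, as far as these compounds go, is whether methoxy would read the same with a longer chain.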